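The source may report more compounds than this note shows. Statements on the series, on what has been measured and on what is new or still open speak of the compounds shown alone.

Measured so far: compound 1 `O=c1c2cn(C3COC3)nc2nc(SCc2cccc(F)c2)n1-c1ccccc1` gives 50%; compound 2 `CC(Sc1nc2c(cnn2C)c(=O)n1-c1ccccc1)c1cccnc1` gives 95%.

In an assay on PEO1 cells for inhibition of Retinaldehyde dehydrogenase 3 (Homo sapiens), read by flow cytometry, with a stated time of 30 min, tested at 1 uM (on this read-out lower numbers stand for less inhibition and higher numbers for more inhibition at the one concentration tested (going by the name of the read-out)), compound 2 gives 95%, the highest of the two numbers, with compound 1 the nearest at a value lower by a gap that lies beyond the scatter. Compound 3 `CC(Sc1nc2c(cnn2C)c(=O)n1-c1ccccc1)c1ccccc1` differs from compound 2 by one change: phenyl in place of pyridin-3-yl on a saturated chain carbon bound to a saturated chain carbon and a sulfur. Among the measured compounds shown here, no measured pair shows this change, so its effect is unknown. The step expected from it in this assay is small, a slight loss or none beyond the scatter: a number 10 percentage points lower from compound 2 to compound 3 (within the scatter). Compound 3 is therefore estimated at 85%, within 60% to 98%.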

Compound 3, a percentage reported as inhibition, at one concentration (the size of the read-out at that concentration, not a potency): 47%
The estimate for compound 3 lay 38 percentage points above the measured number; measured number below the stated range.
By their numbers in this assay, from the lowest: compounds 3 and 1 (each within the scatter of the next); then compound 2.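

In this assay, phenyl in place of pyridin-3-yl on a saturated chain carbon bound to a saturated chain carbon and a sulfur gives a number 48 percentage points lower from compound 2 to compound 3 (beyond the scatter). The two groups have the same count of heavy atoms and differ by one ring nitrogen, so that single atom is enough to move the read-out beyond the scatter at this position. Nothing available accounts for the size of this step. The compounds shown leave open how pyridin-4-yl or pyrimidin-5-yl would read at this position. They also leave open how an amine on the phenyl ring would read.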